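Swapping the aryl on the hydrazone: compound 4 expected

The source may hold more compounds than are shown below. What is called first, only, known or untested is meant among the compounds shown, and "the series" means these compounds.

Three compounds sharing one core differ only in the aryl group on the carbon double-bonded to nitrogen. Compound 1 `COc1ccc(/C=N/NC(=O)Nc2ccc(Oc3ccnc4cc(OCCCN5CCCCC5)c(OC)cc34)c(F)c2)cc1` carries a 4-methoxyphenyl there, and in a functional assay on MKN-45 cells (Homo sapiens) for cytotoxicity, read by MTT assay, with a stated time of 72 h (a lower number here means a stronger inhibitor, a higher number a weaker inhibitor), compound 1 gives 660 nM. Compound 2 `COc1cc2c(Oc3ccc(NC(=O)N/N=C/c4ccc(C(F)(F)F)cc4)cc3F)ccnc2cc1OCCCN1CCCCC1` gives 630 nM, and compound 3 `COc1cc2c(Oc3ccc(NC(=O)N/N=C/c4ccc(Cl)cc4Cl)cc3F)ccnc2cc1OCCCN1CCCCC1` gives 460 nM. Compound 3 stands alongside the other two: the gaps from compound 1 and compound 2 to compound 3 are both inside the scatter, as the steps of a 1.4-fold lower number from compound 1 to compound 3 (0.16 log units; within the scatter) and a 1.4-fold lower number from compound 2 to compound 3 (0.14 log units; within the scatter) show, and the step of a 1.0-fold lower number from compound 1 to compound 2 (0.02 log units; within the scatter) is likewise inside it.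

Compound 4 `COc1cc2c(Oc3ccc(NC(=O)N/N=C/c4ccc(OC(F)(F)F)cc4)cc3F)ccnc2cc1OCCCN1CCCCC1` makes one more change at the same place: 4-(trifluoromethoxy)phenyl in place of 2,4-dichlorophenyl on a carbon with a double bond to nitrogen. Every comparable swap of this aryl group so far has left this assay unmoved beyond its scatter, so no step beyond the scatter is expected here either, which means a 1.3-fold higher number from compound 3 to compound 4 (0.12 log units; within the scatter). Compound 4 is therefore estimated at 600 nM, with a range from 300 nM to 1200 nM.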

Compound 4, half-maximal inhibitory concentration: 630 nM
Beside the measured number, compound 4's estimate is 1.1-fold (0.02 log units) below it, and the stated range covers the measured number.
By their numbers in this assay, from the lowest: compounds 3, 2, 4 and 1 (each within the scatter of the next).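

In this assay, placing an oxygen between the ring and the fluorinated carbon gives no change at the digits printed from compound 2 to compound 4 (within the scatter), and replacing the methyl of the methoxy group with trifluoromethyl gives a 1.0-fold lower number from compound 1 to compound 4 (0.02 log units; within the scatter). Exchanging 2,4-dichlorophenyl for 4-(trifluoromethoxy)phenyl, which has more heavy atoms and a hydrogen-bond acceptor, gives a 1.4-fold higher number from compound 3 to compound 4 (0.14 log units; within the scatter), so neither of these differences moves the number beyond the scatter at this carbon with a double bond to nitrogen. No supporting evidence bears on this result.

As far as these compounds go, the four compounds show only substituted phenyl groups at this place, so the reach of this flat response remains open. An amine or a carboxylic acid on the ring, or a longer chain in place of the ring's small substituents, could still show whether this assay responds to a change here.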